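This account rests on a few compounds, and the source may have more. Where it says the series, first, only, none or still open, it means among the compounds named here.

Measured so far in a functional assay on isolated protein for inhibition of Glucose-dependent insulinotropic receptor (Homo sapiens), read by HTRF and cAMP accumulation; on this read-out higher numbers stand for an effect only at larger amounts of compound and lower numbers for an effect already at smaller amounts:
- compound 1 `Cc1nc(S(C)(=O)=O)ccc1Oc1ncnc(OC2CCN(C(=O)O[C@H](C)C(F)(F)F)CC2)c1F`: 9.2 nM
- compound 2 `Cc1nc(S(C)(=O)=O)ccc1Oc1ncnc(OC2CCN(C(=O)c3nc(C(C)(C)F)no3)CC2)c1F`: 43.4 nM
- compound 3 `CCc1cnc(C(=O)N2CCC(Oc3ncnc(Oc4ccc(S(C)(=O)=O)nc4C)c3F)CC2)nc1`: 4.7 nM

Compound 3 carries the lowest of the three numbers. Its nearest neighbour is compound 1; the step of a 2.0-fold lower number from compound 1 to compound 3 (0.29 log units; within the scatter) stays within the scatter, so no order between compound 1 and compound 3 is claimed. Compound 2 stands apart from both: a 4.7-fold higher number from compound 1 to compound 2 (0.67 log units; beyond the scatter) and a 9.2-fold lower number from compound 2 to compound 3 (0.97 log units; beyond the scatter) are each beyond the scatter, and both concern the whole group on the carbonyl carbon.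

Compound 4 `Cc1nc(S(C)(=O)=O)ccc1Oc1ncnc(OC2CCN(C(=O)c3ncc(Cl)cn3)CC2)c1F` differs from compound 3 by chloro in place of ethyl on an aromatic carbon. Going by the values given here, no measured step bears directly on this change: the three measured steps all exchange the entire group on the carbonyl carbon rather than one substituent on a retained ring, and the pyrimidine of compound 3 is kept in compound 4. The steps into compound 3, a 2.0-fold lower number from compound 1 to compound 3 (0.29 log units; within the scatter) and a 9.2-fold lower number from compound 2 to compound 3 (0.97 log units; beyond the scatter), set the scale for whole-group swaps; a single-substituent exchange on the same ring is expected to move the number less, with no direction established by the data. The step from compound 3 to compound 4 is therefore expected to be small, a 1.3-fold higher number from compound 3 to compound 4 (0.11 log units; within the scatter), within the scatter. Compound 4 is estimated at 6 nM, with a range from 2.5 nM to 15 nM.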

Compound 4, half-maximal effective concentration: 6.12 nM
Compound 4: the middle estimate sits 1.0-fold (0.01 log units) below what was measured; measured number inside the range.
By their numbers in this assay, from the lowest: compounds 3, 4 and 1 (each within the scatter of the next); then compound 2.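

In this assay, going by these compounds alone, this is the first exchange of a single substituent on a retained ring rather than of the whole group on the carbonyl carbon: a 1.3-fold higher number from compound 3 to compound 4 (0.11 log units; within the scatter) shows that chloro and ethyl, two atoms from the ring nitrogen and para to a large group, are not told apart by this read-out. With chloro in place of ethyl, the six-membered aromatic ring with 2 nitrogen keeps its separation from the group carrying the five-membered aromatic ring, seen in a 7.1-fold lower number from compound 2 to compound 4 (0.85 log units; beyond the scatter) as a step beyond the scatter, and keeps its closeness to 1-(trifluoromethyl)ethoxy, seen in a 1.5-fold lower number from compound 1 to compound 4 (0.18 log units; within the scatter) as a step within the scatter, so two pyrimidin-2-yl groups now sit with that carbamate group and only compound 2 stands apart. No measured data bear on the reason for any of these steps.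

This single pair does not tell how a methoxy, a nitrile, an amine or a longer chain such as propyl would read at this position. As far as these compounds go, whether a hydrogen there would read the same as chloro and ethyl also remains open.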